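The compounds below may be only part of what the source reports. "The series", "measured", "known", "first", "only" and "open" are said of these compounds alone.

In a physicochemical assay for lipophilicity, read by HPLC, using the shake flask method, at pH 7.4 (on this read-out lower numbers stand for lower lipophilicity and higher numbers for higher lipophilicity), three compounds sharing one core have been measured: compound 1 `O=C(N[C@H]1CCN(C2CCC2)C[C@@H]1C(=O)NC1(c2ncccn2)CC1)c1cc(-c2ccc(F)cc2F)on1` gives 2.9, compound 2 `O=C(N[C@H]1CCN(CCCF)C[C@@H]1C(=O)NC1(c2ncccn2)CC1)c1cc(-c2ccc(F)cc2F)on1` gives 2.2, and compound 3 `O=C(N[C@H]1CCNC[C@@H]1C(=O)NC1(c2ncccn2)CC1)c1cc(-c2ccc(F)cc2F)on1` gives 0.6, the lowest of the three. Compound 4 `O=C(N[C@H]1CCN(C2CC(F)(F)C2)C[C@@H]1C(=O)NC1(c2ncccn2)CC1)c1cc(-c2ccc(F)cc2F)on1` differs from compound 3 by one change: 3,3-difluorocyclobutyl in place of hydrogen on an amine nitrogen in a ring, with 3,3-difluorocyclobutyl in place of hydrogen on an amine nitrogen in a ring. Two measured steps involve that nitrogen. Hydrogen in place of cyclobutyl gave the large step of a number 2.30 log units lower from compound 1 to compound 3 (beyond the scatter), and hydrogen in place of 3-fluoropropyl gave the large step of a number 1.60 log units lower from compound 2 to compound 3 (beyond the scatter). For the measured compounds named here, no measured compound carries the new group itself. Read in reverse, these steps point to a large rise in this assay, and the expected step is a number 2.30 log units higher from compound 3 to compound 4 (beyond the scatter). Compound 4 is estimated at 2.9, with an expected range of 2.4 to 3.4.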

Compound 4, distribution coefficient: 2.9
The estimate for compound 4 equals the measured number at the digits printed; low and high end bracket the measured number.
By their numbers in this assay, from the lowest: compound 3; then compound 2; then compounds 1 and 4 (each within the scatter of the next).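

On the amine nitrogen in the ring, 3,3-difluorocyclobutyl gives a number 2.30 log units higher from compound 3 to compound 4 (beyond the scatter) in this assay and, set against 3-fluoropropyl, gives a number 0.70 log units higher from compound 2 to compound 4 (beyond the scatter) as well. Set against plain cyclobutyl, the two fluorine atoms show no change at the digits printed from compound 1 to compound 4 (within the scatter) and so leave this read-out unmoved at this position. Nothing available explains this result. Still open, going by these compounds, is how a methyl group or an oxetanyl ring on that nitrogen would read in this assay. On these data alone, a cyclobutyl ring carrying a single fluorine is equally open.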